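A few compounds are considered here, and "the series" means these few. Any claim that something is new, unique, unknown or untested is made for them only; others in the source may bear on it.

Compound 1 `O=C(CCCCCCc1ccccc1)N1CCCC1` — in an assay on HEK293 cells for inhibition of N-acylethanolamine-hydrolyzing acid amidase (Rattus norvegicus), read by LC-MS, with a stated time of 30 min (on this read-out lower numbers stand for stronger inhibition and higher numbers for weaker inhibition), compound 1 gives 12900 nM.
Compound 2 `Cc1cccc(CCCCCCC(=O)N2CCCC2)c1` — in this assay compound 2 gives 8300 nM.
Compound 3 `COc1cccc(CCCCCCC(=O)N2CCCC2)c1` — in this assay compound 3 gives > 100000 nM, which is a limit of the assay and not a number (the limit of > 100000 nM in this assay, at which 1 of the 3 values shown sits).

Compound 3 thus stands at the weak edge of what this assay reports; of the three compounds it alone has no number. The step of an at least 7.7-fold higher number from compound 1 to compound 3 (0.88 log units; beyond the scatter) and the step of an at least 12-fold higher number from compound 2 to compound 3 (1.08 log units; beyond the scatter) both end at this limit, whereas the step of a 1.6-fold lower number from compound 1 to compound 2 (0.19 log units; within the scatter) stays inside the scatter. Compound 4 `COC(=O)c1cccc(CCCCCCC(=O)N2CCCC2)c1` differs from compound 3 by methoxycarbonyl in place of methoxy on an aromatic carbon. For the measured compounds named here, no measured step involves a methoxycarbonyl group, so none bears directly on this change; the two steps ending at compound 3 show only that the methoxy carries the weak reading. Whether methoxycarbonyl behaves more like methoxy or more like methyl cannot be read from these three compounds, and a wide range follows. Compound 4 is expected to give an estimated 60000 nM, within 15000 nM to 300000 nM. The expected step is an at least 1.6-fold lower number from compound 3 to compound 4 (0.22 log units; that floor lies within the scatter), with a real chance that only a limit is reported again.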

Compound 4, half-maximal inhibitory concentration: > 100000 nM
Compound 4 gave a limit, no number; the forecaster's own chance of this, stated with the estimate: 40%; at least 1.6-fold (0.22 log units) between middle value and limit.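

With methoxycarbonyl in place of methoxy on this aromatic carbon, compound 4 also sits at a limit of the assay and not a number, so the weak reading in this assay is no longer tied to methoxy alone: the limit of > 100000 nM in this assay, at which 2 of the 4 values shown sit.

Measured against the compounds that have numbers, this substitution gives an at least 12-fold higher number from compound 2 to compound 4 (1.08 log units; beyond the scatter) and an at least 7.7-fold higher number from compound 1 to compound 4 (0.88 log units; beyond the scatter). The step between the two limits cannot be read, so these compounds do not place methoxy and methoxycarbonyl in any order.

Among the four compounds, only hydrogen and methyl at this place give numbers, and both oxygen-bearing groups end at the limit. Going by these compounds, it remains open whether a chlorine atom, an ethyl group or a carboxylic acid here would give a number, and whether methoxy or methoxycarbonyl would read the same on another carbon of the ring.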